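The source may hold more compounds than are shown below. What is called first, only, known or untested is meant among the compounds shown, and "the series" means these compounds.

Compound 1 `Fc1ccc(-c2nc3cnc(Nc4ccc(C(F)(F)F)cn4)cc3[nH]2)cc1F` was measured in a physicochemical assay for solubility, using the shake flask method, in phosphate buffer, measured as kinetic solubility, with a stated time of 20 h, at pH 6.5 (a lower number here means a less soluble compound, a higher number a more soluble compound), and gives only a limit, < 5000 nM. Compound 2 `Fc1ccc(-c2nc3cnc(Nc4cc(C(F)(F)F)ccn4)cc3[nH]2)cc1F` likewise gives a limit in this assay, < 5000 nM. Compound 3 `Fc1ccc(Nc2cc3[nH]c(-c4ccc(F)c(F)c4)nc3cn2)nc1` also gives a limit, < 5000 nM. Every value shown is therefore a limit, and compound 1 stands with the others at the limit of < 5000 nM in this assay, at which 3 of the 3 values shown sit. For the measured compounds named here, the one comparison in this set, a step that the two limits leave unreadable from compound 1 to compound 3, is unreadable for this reason. Compound 4 `FC(F)(F)c1ccc(Nc2cc3[nH]c([C@H]4CC[C@H](C(F)(F)F)CC4)nc3cn2)nc1` differs from compound 1 by 4-(trifluoromethyl)cyclohexyl in place of 3,4-difluorophenyl on an aromatic carbon. Going by the values given here, no measured step bears on this change, so its size in this assay cannot be predicted. Compound 4 is expected to stay near the limit, with an estimated 3000 nM within 500 nM to 15000 nM; the expected step is a step that the limit leaves unreadable from compound 1 to compound 4.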

Compound 4, solubility: < 5000 nM
Compound 4 was reported as a limit (the forecaster's own chance of this, stated with the estimate: 70%); the middle value does not contradict the limit.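

In this assay, for the compounds shown here, compound 1 and compound 4 both give only limits, and no step between them can be read. The compounds shown leave open the actual solubility of each one, since all rest at one limit: the limit of < 5000 nM in this assay, at which 4 of the 4 values shown sit.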